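This account rests on a few compounds, and the source may have more. Where it says the series, first, only, none or still open, it means among the compounds named here.

Series notes. Compound 1 `S=C(Nc1ccccc1)OCCc1ccccn1` carries the unsubstituted core; in an ADME assay on MT4 cells (Homo sapiens) for cytotoxicity, read by MTT assay (a lower number here means that less compound is tolerated, a higher number that more compound is tolerated), compound 1 gives > 100000 nM, which is a limit of the assay and not a number. Compound 2 `S=C(Nc1cccc(Cl)c1)OCCc1ccccn1` gives 47000 nM in this assay, and compound 3 `Cc1ccc(NC(=S)OCCc2ccccn2)cc1` gives 75000 nM. Compound 3 thus holds the higher of the two numbers, with compound 2 within the scatter of it. The change to compound 4 `CCc1ccc(NC(=S)OCCc2ccccn2)cc1` is methyl in place of hydrogen on a saturated chain carbon bound to an aromatic carbon. For the measured compounds named here, two measured steps bear on it: an at least 2.1-fold lower number from compound 1 to compound 2 (0.32 log units; beyond the scatter) and an at least 1.3-fold lower number from compound 1 to compound 3 (0.12 log units; that floor lies within the scatter). Both start from the limit of > 100000 nM in this assay, at which 1 of the 3 values shown sits, so only a floor of each is known, and the methyl step lies within the scatter. The step to compound 4 in this assay is expected to be small, at most a modest lowering: a 1.3-fold lower number from compound 3 to compound 4 (0.10 log units; within the scatter). The estimate for compound 4 is 60000 nM, with a range from 30000 nM to 120000 nM.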

Compound 4, half-maximal cytotoxic concentration: 44000 nM
Estimate against measurement, compound 4: 1.4-fold (0.13 log units) above; measured number inside the range.
By their numbers in this assay, from the lowest: compounds 4, 2 and 3 (each within the scatter of the next). At a limit, above all of these: compound 1.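

In this assay, the change from methyl to ethyl, on a saturated chain carbon bound to an aromatic carbon, gives a 1.7-fold lower number from compound 3 to compound 4 (0.23 log units; within the scatter), so one added carbon at this position does not separate the two compounds. Measured from the unsubstituted core, ethyl gives an at least 2.2-fold lower number from compound 1 to compound 4 (0.35 log units; beyond the scatter), whereas the floor for methyl in place of hydrogen on the aromatic carbon lay within the scatter. Compound 1 stands at a limit, so this step is only a floor: the limit of > 100000 nM in this assay, at which 1 of the 4 values shown sits.

Still open, from the compounds shown here alone, is whether a longer chain such as propyl would move the number beyond the scatter from compound 3. Also open, going by these compounds, is how an amine or a carboxylic acid at this position would read in this assay.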